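The compounds below may be only part of what the source reports. "The series", "measured", "known", "first", "only" and "open" are said of these compounds alone.

Compound 1 `Cc1ccccc1-n1nncc1CN1C(=O)C2(C(C#N)=C(N)Oc3c(N)cc4nc5ccccc5nc4c32)c2ccccc21` gives in a functional assay on HCT-116 cells (Homo sapiens) for antiproliferative activity, read by MTT assay, with a stated time of 48 h; on this read-out lower numbers stand for stronger inhibition and higher numbers for weaker inhibition > 50000 nM, which is a limit of the assay.
Compound 2 `Cc1ccc(C)c(-n2nncc2CN2C(=O)C3(C(C#N)=C(N)Oc4c(N)cc5nc6ccccc6nc5c43)c3ccccc32)c1` gives in this assay > 50000 nM, again a limit of the assay.
Compound 3 `CCc1cccc(CC)c1-n1nncc1CN1C(=O)C2(C(C#N)=C(N)Oc3c(N)cc4nc5ccccc5nc4c32)c2ccccc21` gives in this assay 37600 nM.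

Among the compounds with values here, compound 3 thus stands as the only compound of the three with an actual number; the other two sit at the limit of > 50000 nM in this assay, at which 2 of the 3 values shown sit. The step that the two limits leave unreadable from compound 1 to compound 2 cannot be read. The steps of an at least 1.3-fold lower number from compound 1 to compound 3 (0.12 log units; that floor lies within the scatter) and an at least 1.3-fold lower number from compound 2 to compound 3 (0.12 log units; that floor lies within the scatter) have floors that lie within the usual scatter, so nothing shows that the phenyl ring on the aromatic nitrogen of the triazole moves potency at all.

Compound 4 `N#CC1=C(N)Oc2c(N)cc3nc4ccccc4nc3c2C12C(=O)N(Cc1cnnn1-c1ccc(F)c(Cl)c1)c1ccccc12` carries the change (3-chloro-4-fluorophenyl in place of 2,6-diethylphenyl on an aromatic nitrogen). The two steps that bear on it, from compound 1 and from compound 2 to compound 3, both swap substituents on that same phenyl ring and neither reached beyond the scatter. No shown step therefore supports a move in either direction, and the expected step of a 1.2-fold higher number from compound 3 to compound 4 (0.08 log units; within the scatter) is one of no change beyond the scatter. Compound 4 is accordingly estimated at 45000 nM in this assay, with a range from 15000 nM to 150000 nM, and a fair chance that the assay reports only a limit.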

Compound 4, half-maximal inhibitory concentration: > 50000 nM
Compound 4: only a limit was reported (the forecaster's own chance of this, stated with the estimate: 55%); at least 1.1-fold (0.04 log units) between middle value and limit.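

Within the data shown here, with chlorine and fluorine on the phenyl ring in place of the alkyl groups carried by the earlier compounds, the change to 3-chloro-4-fluorophenyl gives an at least 1.3-fold higher number from compound 3 to compound 4 (0.12 log units; that floor lies within the scatter) in this assay, so a halogen-bearing ring on this aromatic nitrogen also produces no move beyond the scatter. The steps from compound 1 and from compound 2 to compound 4 join two limits and cannot be read. The series now gathers at one end of the read-out: the limit of > 50000 nM in this assay, at which 3 of the 4 values shown sit.

Whether any group on this phenyl ring can bring the antiproliferative read-out clear of that limit remains open, and the compounds shown cannot say whether this position influences potency at all. As far as these compounds go, how an amine or a carboxylic acid on the ring would behave, or a longer alkyl chain on the aromatic nitrogen in place of the ring, also remains unknown.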